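The source may hold more compounds than are shown below. What is called first, only, known or untested is meant among the compounds shown, and "the series" means these compounds.

Working notes on the series. The shared core, as it stands in compound 1 `CCOC(=O)CC(=O)N1CCSC1COc1ccccc1OC`, carries a side chain on the ring nitrogen that is varied across the measured set. Compound 1 gives 21 mg/kg in a functional assay on the whole organism for inhibition, with Cavia porcellus as the target (on this read-out higher numbers stand for an effect only at larger amounts of compound and lower numbers for an effect already at smaller amounts), the lowest of the three numbers. Compound 2 `COc1ccccc1OCC1SCCN1C(=O)Cn1ccnc1` gives 50 mg/kg, and the change from compound 1 reads a 2.4-fold higher number from compound 1 to compound 2 (0.38 log units; beyond the scatter). Compound 3 `COc1ccccc1OCC1SCCN1C(=O)CC(C)=O` gives 30 mg/kg, with a 1.4-fold higher number from compound 1 to compound 3 (0.15 log units; within the scatter) from compound 1 and a 1.7-fold lower number from compound 2 to compound 3 (0.22 log units; within the scatter) from compound 2. All three measured steps sit on the saturated chain carbon bound to the carbonyl carbon.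

Compound 4 `CCOC(=O)CC(=O)N1CCSC1COc1ccccc1O` differs from compound 1 at another place: hydrogen in place of methyl on an oxygen on an aromatic ring. Cut one bond further out, the difference reads methoxy to hydroxy. Going by the values given here, no measured step touches the oxygen on the aromatic ring, so the measured steps give no direct guide; the only bearing is that the side-chain changes moved the read-out by at most a modest amount, and a change leaving a single carbon is expected to be no larger. The expected step is a 1.2-fold higher number from compound 1 to compound 4 (0.08 log units; within the scatter), not beyond the scatter. Compound 4 is estimated at 25 mg/kg, within 10 mg/kg to 65 mg/kg.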

Compound 4, dose for half-maximal effect: 20 mg/kg
Beside the measured number, compound 4's estimate is 1.3-fold (0.10 log units) above it; low and high end bracket the measured number.
By their numbers in this assay, from the lowest: compounds 4, 1, 3 and 2 (each within the scatter of the next, the first and the last beyond it).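

In this assay hydrogen in place of methyl on an oxygen on an aromatic ring gives a 1.1-fold lower number from compound 1 to compound 4 (0.02 log units; within the scatter) and so the two numbers cannot be told apart. Going by these compounds alone, this is the first reading away from the side chain, and it shows that methoxy to hydroxy, with the loss of a single carbon, leaves no measurable mark on this read-out for this pair. Within the data shown here, the only step beyond the scatter among those read from compound 1 remains the side-chain one, a 2.4-fold higher number from compound 1 to compound 2 (0.38 log units; beyond the scatter) and nothing at hand bears on why the change at the oxygen is so flat.

On these data alone, whether a larger group on that oxygen, such as ethoxy or a longer chain, would read the same stays open. Also open, as far as these compounds go, is whether hydroxy reads the same with the side chains of compound 2 and compound 3.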